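A 3-methylphenyl group replaces 4-(dimethylamino)phenyl

The source may report more compounds than this note shows. Statements on the series, on what has been measured and on what is new or still open speak of the compounds shown alone.

In a functional assay on HCT-116 cells (Homo sapiens) for inhibition, read by CCK-8 assay, with a stated time of 48 h (on this read-out lower numbers stand for stronger inhibition and higher numbers for weaker inhibition), compound 1 `COc1cc(-c2ccnc3cc(-c4ccc(C)cc4)nn23)cc(OC)c1OC` gives 48 nM, compound 2 `COc1cc(-c2ccnc3cc(-c4ccccc4)nn23)cc(OC)c1OC` gives 3880 nM and compound 3 `COc1cc(-c2ccnc3cc(-c4ccc(N(C)C)cc4)nn23)cc(OC)c1OC` gives 2050 nM. Compound 3 therefore sits in the high pair of numbers: a 1.9-fold lower number from compound 2 to compound 3 (0.28 log units; within the scatter) stays within the scatter, whereas a 43-fold higher number from compound 1 to compound 3 (1.63 log units; beyond the scatter) lies beyond it. Compound 4 `COc1cc(-c2ccnc3cc(-c4cccc(C)c4)nn23)cc(OC)c1OC` differs from compound 3 by 3-methylphenyl in place of 4-(dimethylamino)phenyl on an aromatic carbon. Among the compounds with values here, the closest evidence is the large 81-fold higher number from compound 1 to compound 2 (1.91 log units; beyond the scatter), together with the step to compound 3 above, but no measured compound carries the 3-methylphenyl group. Only part of that difference is expected to carry over. The expected result is a moderate drop, a 5.1-fold lower number from compound 3 to compound 4 (0.71 log units; beyond the scatter). For compound 4 the estimated value is 400 nM, within an expected range of 60 nM to 3000 nM.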

Compound 4, half-maximal inhibitory concentration: 6150 nM
Estimate against measurement, compound 4: 15-fold (1.19 log units) below, and the stated range ends below it.
By their numbers in this assay, from the lowest: compound 1; then compounds 3, 2 and 4 (each within the scatter of the next, the first and the last beyond it).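

In this assay, 3-methylphenyl in place of 4-methylphenyl gives a 130-fold higher number from compound 1 to compound 4 (2.11 log units; beyond the scatter), so the low number of compound 1 depends on where the methyl sits and not merely on its presence. Methyl in place of hydrogen now gives a 1.6-fold higher number from compound 2 to compound 4 (0.20 log units; within the scatter), which stays within the scatter, while 3-methylphenyl in place of 4-(dimethylamino)phenyl gives a 3.0-fold higher number from compound 3 to compound 4 (0.48 log units; beyond the scatter). Nothing available explains these differences. Going by these compounds, whether an ethyl or a methoxy group in place of the methyl of 4-methylphenyl would keep the low number remains open.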